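Shortening the amide chain at the saturated chain carbon

A few compounds are considered here, and "the series" means these few. Any claim that something is new, unique, unknown or untested is made for them only; others in the source may bear on it.

Measured compounds in an assay on isolated protein for inhibition of Myeloperoxidase (Homo sapiens), read by ELISA, with a stated time of 5 min; on this read-out higher numbers stand for weaker inhibition and lower numbers for stronger inhibition:
- compound 1, `NCCCc1c[nH]c2c(F)cccc12`; compound 1 gives 26 nM
- compound 2, `NC(=O)CCCCc1c[nH]c2ccc(F)cc12`; compound 2 gives 43 nM
- compound 3, `NCCSCCCc1c[nH]c2c(F)cccc12`; compound 3 sits at the assay limit, > 100 nM, which is a limit and not a number.

Compound 2 and compound 1 lie within the scatter of each other, so neither can be called the weaker or stronger of the two; compound 3 stands apart at the limit (the limit of > 100 nM in this assay, at which 1 of the 3 values shown sits).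

The unmeasured compound 4, `NC(=O)CCCc1c[nH]c2ccc(F)cc12`, differs from compound 2 by carbamoyl in place of carbamoylmethyl on a saturated chain carbon, three bonds along the chain from an aromatic carbon. Among the measured compounds shown here, the only measured step at the same position is an at least 3.8-fold higher number from compound 1 to compound 3 (0.58 log units; beyond the scatter), which enlarged the chain terminus and pushed the number to the limit. The change from compound 2 to compound 4 runs the other way, removing one chain carbon while keeping the carbamoyl terminus, so that step is only loosely informative. In this assay a step no larger than the scatter, in either direction, is therefore expected.

Compound 4 is estimated at 50 nM, with a range of 20 nM to 150 nM.

The expected step from compound 2 to compound 4 is a 1.2-fold higher number from compound 2 to compound 4 (0.07 log units; within the scatter).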

Compound 4, half-maximal inhibitory concentration: 18 nM
Estimate against measurement, compound 4: 2.8-fold (0.44 log units) above; measured number below the stated range.
By their numbers in this assay, from the lowest: compounds 4, 1 and 2 (each within the scatter of the next, the first and the last beyond it). At a limit, above all of these: compound 3.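

In this assay carbamoyl in place of carbamoylmethyl gives a 2.4-fold lower number from compound 2 to compound 4 (0.38 log units; beyond the scatter) and so shows that the number responds to the length of the amide chain at this saturated chain carbon, with the shorter chain on the lower side. Among the compounds shown here, the only earlier step at this position, an at least 3.8-fold higher number from compound 1 to compound 3 (0.58 log units; beyond the scatter) as printed, ends at a limit of the assay and changes an amine terminus, so the new step is the first here with a number at both ends and the first on an amide terminus. The data in hand offer no measurement that accounts for this step, and the limit of the assay has no bearing on it.

Open, as far as these compounds go, is how far the trend runs: one pair cannot show whether a still shorter chain or a longer chain of another length would continue it, or whether a carboxylic acid, an amine or a nitrile in place of the amide on the core of compound 4 would behave alike. Open too, from the compounds shown here alone, is whether the same shortening would shift the number on the core of compound 1, which carries its fluorine at a different place from compound 2 and compound 4.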